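This account rests on a few compounds, and the source may have more. Where it says the series, first, only, none or still open, it means among the compounds named here.

Measured so far in a functional assay on HT-29 cells (Homo sapiens) for cytotoxicity, read by MTT assay, with a stated time of 72 h; on this read-out lower numbers stand for stronger inhibition and higher numbers for weaker inhibition:

- compound 1 `COc1cc2c(Oc3ccc(NC(=O)N/N=C/c4ccc(C(F)(F)F)cc4)cc3F)ccnc2cc1OCCCN1CCCCC1`: 660 nM
- compound 2 `COc1cc2c(Oc3ccc(NC(=O)N/N=C/c4ccc(OC(F)(F)F)cc4)cc3F)ccnc2cc1OCCCN1CCCCC1`: 510 nM
- compound 3 `COc1cc2c(Oc3ccc(NC(=O)N/N=C/c4ccc(O)cc4)cc3F)ccnc2cc1OCCCN1CCCCC1`: 470 nM

Compound 1 carries the highest of the three numbers, but the gaps are small: a 1.3-fold lower number from compound 1 to compound 2 (0.11 log units; within the scatter) and a 1.4-fold lower number from compound 1 to compound 3 (0.15 log units; within the scatter) both fall within the scatter, as does a 1.1-fold lower number from compound 2 to compound 3 (0.04 log units; within the scatter). On these numbers the three compounds cannot be told apart, and the substituent on the terminal aromatic ring has so far made no difference that survives repeated measurement.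

Compound 4 `COc1cc2c(Oc3ccc(NC(=O)N/N=C/c4cc5ccccc5[nH]4)cc3F)ccnc2cc1OCCCN1CCCCC1` differs from compound 1 in one place: 1H-indol-2-yl in place of 4-(trifluoromethyl)phenyl on a carbon with a double bond to nitrogen. The measured steps only exchange the substituent on that terminal ring; none of them exchanges the ring itself, so they bear on this change only loosely. What they do show is that this end of the molecule has tolerated three different groups without a step beyond the scatter, and a comparable outcome is the most defensible expectation here. Among the compounds with values here, the hydrogen-bond donor that enters has no measured precedent, so the range is kept wide.

The expected step in this assay for compound 4 is a 1.3-fold lower number from compound 1 to compound 4 (0.12 log units; within the scatter), that is, no change beyond the scatter. Compound 4 is therefore estimated at 500 nM, with a range from 180 nM to 1500 nM.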

Compound 4, half-maximal inhibitory concentration: 820 nM
Beside the measured number, compound 4's estimate is 1.6-fold (0.21 log units) below it; the measured number falls inside the stated range.
By their numbers in this assay, from the lowest: compounds 3, 2, 1 and 4 (each within the scatter of the next).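

In this assay, within the data shown here, exchanging the whole terminal ring system, and not only a substituent on it, gives no step beyond the scatter against any of the earlier compounds (a 1.2-fold higher number from compound 1 to compound 4 (0.09 log units; within the scatter); a 1.6-fold higher number from compound 2 to compound 4 (0.21 log units; within the scatter); a 1.7-fold higher number from compound 3 to compound 4 (0.24 log units; within the scatter)). The carbon with a double bond to nitrogen therefore now carries 1H-indol-2-yl, with its five-membered aromatic ring holding one hetero atom, as well as the three 4-substituted phenyl groups, and all four compounds remain within the scatter of one another on this read-out. No measurement at hand explains this insensitivity.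

As far as these compounds go, whether 4-aminophenyl, 4-carboxyphenyl or an open-chain alkyl group on that same carbon would also stay within the scatter remains open, so the limits of what this position accepts are still undefined. All four compounds share the rest of the molecule, which leaves open whether the same insensitivity would hold with a morpholine in place of the terminal piperidine of the side chain.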